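The source may hold more compounds than are shown below. What is called first, only, known or untested is meant among the compounds shown, and "the series" means these compounds.

Going by the values given here, compound 1 `COc1cccc(CNCCCNc2ccnc3cc(Oc4ccccc4)ccc23)c1O` is the best-dissolving member of the three compounds measured so far: in a physicochemical assay for solubility, with a stated time of 18 h, at pH 7.4 (on this read-out lower numbers stand for lower solubility and higher numbers for higher solubility), compound 1 gives 14500 nM. Compound 2 `CC(C)CCc1ccc2c(NCCCNCc3ccco3)ccnc2c1` sits well below it, and in this assay compound 2 gives 4200 nM. Compound 3 `Fc1ccc(Cc2ccc3c(NCCCNCc4ccco4)ccnc3c2)c(Cl)c1` is the near twin of compound 2, and in this assay compound 3 gives 4200 nM. Among the compounds with values here, compound 1 thus stands highest of the three, separated from compound 2 and from compound 3 by gaps beyond the scatter, while the only single-point step in the set, no change at the digits printed from compound 2 to compound 3 (within the scatter), shows that exchanging isobutyl for a 2-chloro-4-fluorophenyl on a saturated chain carbon left solubility where it was.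

Compound 4 `COc1cccc(CNCCCNc2ccnc3cc(CC(C)C)ccc23)c1O` keeps everything of compound 1 except one group on the core: isobutyl in place of phenoxy on an aromatic carbon. Within the data shown here, no measured step covers exactly this exchange, since compound 2 and compound 3 differ from compound 1 at the far end of the linker as well. Among the measured compounds shown here, the one step that bears on it, from compound 2 to compound 3, shows an aryl-for-isobutyl swap at the core producing nothing beyond the scatter, so a similarly flat outcome is expected here, a 1.2-fold lower number from compound 1 to compound 4 (0.08 log units; within the scatter). Compound 4 is therefore estimated at 12000 nM, within a range of 5000 nM to 30000 nM.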

Compound 4, solubility: 4200 nM
Estimate against measurement, compound 4: 2.9-fold (0.46 log units) above; measured number below the stated range.
By their numbers in this assay, from the lowest: compounds 2, 3 and 4 (each within the scatter of the next); then compound 1.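

In this assay, the exchange on this aromatic carbon gives a 3.5-fold lower number from compound 1 to compound 4 (0.54 log units; beyond the scatter), so with the rest of compound 1 held fixed, this position of the core does register a change in the read-out. Going by these compounds alone, the only earlier single-point step, no change at the digits printed from compound 2 to compound 3 (within the scatter), concerned a different exchange, made on a saturated chain carbon rather than directly on the aromatic carbon, so its flat outcome does not carry over to this position. Here phenoxy, with its ring of carbon and its oxygen, leaves and isobutyl, with no ring, enters, and the number falls, but no measurement at hand accounts for this fall.

The compounds shown leave open whether the difference follows the ring or the oxygen of phenoxy, a question that a phenyl group or an isobutoxy chain on the same carbon could separate. They also leave open how an amine such as morpholine on this carbon would read out, and whether the exchange of phenoxy for isobutyl gives a step of similar size with a different group at the far end of the linker.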